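This account rests on a few compounds, and the source may have more. Where it says the series, first, only, none or still open, it means among the compounds named here.

Measured so far:
Compound 1 `C#Cc1cccc(Nc2ncnc3ccc(NC(=S)Nc4ccc(S(N)(=O)=O)cc4)cc23)c1` — in a functional assay on A549 cells (Homo sapiens) for antiproliferative activity, read by MTT assay, with a stated time of 72 h (a higher number here means a weaker inhibitor, a lower number a stronger inhibitor), compound 1 gives only a limit of the assay, > 40000 nM.
Compound 2 `NS(=O)(=O)c1ccc(NC(=S)Nc2ccc3ncnc(Nc4ccc(Cl)c(C(F)(F)F)c4)c3c2)cc1` — in this assay compound 2 gives 4500 nM.
Compound 3 `NS(=O)(=O)c1ccc(NC(=S)Nc2ccc3ncnc(Nc4cccc(F)c4)c3c2)cc1` — in this assay compound 3 gives 25900 nM.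

Of the two plain numbers, compound 3 sits highest; the nearest is compound 2, separated by a 5.8-fold higher number from compound 2 to compound 3 (0.76 log units; beyond the scatter). Compound 4 `NS(=O)(=O)c1ccc(NC(=S)Nc2ccc3ncnc(Nc4cccc(Cl)c4)c3c2)cc1` is not yet measured and differs from compound 3 by chloro in place of fluoro on an aromatic carbon. Going by the values given here, two measured steps bear on this. The step of a 5.8-fold higher number from compound 2 to compound 3 (0.76 log units; beyond the scatter) exchanged one halogenated phenyl for another, a modest change, while an at least 1.5-fold lower number from compound 1 to compound 3 (0.18 log units; that floor lies within the scatter) stayed within the scatter. A single heavier halogen is a smaller change than either, so a small shift toward lower numbers, perhaps none beyond the scatter, is expected: a 1.7-fold lower number from compound 3 to compound 4 (0.24 log units; within the scatter). Compound 4 is estimated at 15000 nM, within 5000 nM to 45000 nM.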

Compound 4, half-maximal inhibitory concentration: > 40000 nM
Compound 4 gave a limit, no number (the forecaster's own chance of this, stated with the estimate: 15%); middle value at least 2.6-fold (0.42 log units) from the limit.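

At this position, chloro in place of fluoro brings no gain in this assay, and the step, an at least 1.5-fold higher number from compound 3 to compound 4 (0.18 log units; that floor lies within the scatter), does not firmly settle even the direction of the change. A lone chloro at this position also falls short of the 4-chloro-3-(trifluoromethyl)phenyl group: an at least 8.8-fold higher number from compound 2 to compound 4 (0.94 log units; beyond the scatter). The step between compound 1 and compound 4 cannot be read, as both values are limits: the limit of > 40000 nM in this assay, at which 2 of the 4 values shown sit.

Still open, on these data alone, is whether the trifluoromethyl or the chloro of the 4-chloro-3-(trifluoromethyl)phenyl group matters more. Also open, as far as these compounds go, is how a methoxy or an amine at this position would read.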